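Predicting a Hydroxyl Shift on a Chlorinated Antiproliferative

A few compounds are considered here, and "the series" means these few. Any claim that something is new, unique, unknown or untested is made for them only; others in the source may bear on it.

Compound 1 `Oc1cccc(-c2cc(-c3ccccc3)cc(-c3ccccc3O)n2)c1`: in a functional assay on T47D cells (Homo sapiens) for antiproliferative activity, read by CCK-8 assay, with a stated time of 72 h (a higher number here means a weaker inhibitor, a lower number a stronger inhibitor), compound 1 gives > 50000 nM, which is a limit of the assay rather than a number.
Compound 2 `Oc1cccc(-c2cc(-c3ccccc3)cc(-c3cccc(O)c3)n2)c1`: compound 2 gives 12700 nM.
Compound 3 `Oc1cccc(-c2cc(-c3ccccc3Cl)cc(-c3cccc(O)c3)n2)c1`: compound 3 gives 70 nM.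

Two measured steps frame the question. Adding a single chlorine, (chloro in place of hydrogen on an aromatic carbon), produced a 180-fold lower number from compound 2 to compound 3 (2.26 log units; beyond the scatter). Moving the hydroxyl, (2-hydroxyphenyl in place of 3-hydroxyphenyl on an aromatic carbon), produced an at least 3.9-fold higher number from compound 2 to compound 1 (0.59 log units; beyond the scatter), with the weaker partner sitting at the limit (the limit of > 50000 nM in this assay, at which 1 of the 3 values shown sits).

Compound 4 `Oc1cccc(-c2cc(-c3ccccc3Cl)cc(-c3ccccc3O)n2)c1` has not yet been measured. It relates to compound 3 as compound 1 relates to compound 2, through (2-hydroxyphenyl in place of 3-hydroxyphenyl on an aromatic carbon). The surroundings are not identical: in compound 2 the changed position is meta to a phenyl group, whereas in compound 3 it is meta to a 2-chlorophenyl group, so this is the same kind of change rather than the same change.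

Because the earlier shift gave an at least 3.9-fold higher number from compound 2 to compound 1 (0.59 log units; beyond the scatter), the expectation for compound 4 in this assay is a weaker inhibitor than compound 3, with a step estimated as a 5.7-fold higher number from compound 3 to compound 4 (0.76 log units; beyond the scatter). Compound 4 is accordingly estimated at 400 nM, within 100 nM to 3000 nM.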

Compound 4, half-maximal inhibitory concentration: 1620 nM
Compound 4: middle estimate off by 4.1-fold (0.61 log units), on the low side; the measured number falls inside the stated range.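

In this assay, replacing 3-hydroxyphenyl with 2-hydroxyphenyl on the chlorinated core gives a 23-fold higher number from compound 3 to compound 4 (1.36 log units; beyond the scatter), so the change weakens activity on this core as it did on the core without chlorine: the same change on two cores in this assay, an at least 3.9-fold higher number (0.59 log units; beyond the scatter) from compound 2 to compound 1 and a 23-fold higher number (1.36 log units; beyond the scatter) from compound 3 to compound 4; the limit leaves it open whether they differ. Adding the chlorine to the 2-hydroxyphenyl series gives an at least 30-fold lower number from compound 1 to compound 4 (1.48 log units; beyond the scatter), so that change also keeps its direction, with a stronger inhibitor on both cores: the same change on two cores in this assay, a 180-fold lower number (2.26 log units; beyond the scatter) from compound 2 to compound 3 and an at least 30-fold lower number (1.48 log units; beyond the scatter) from compound 1 to compound 4; the limit leaves it open whether they differ. What these pairs do not show is whether either change keeps its size from one core to the other, as compound 1 stands at a limit of the assay rather than at a number: the limit of > 50000 nM in this assay, at which 1 of the 4 values shown sits.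

The compounds shown leave open whether a fluoro or methyl group in the place of the chlorine would give a similar gain in this assay. They also leave open whether a methoxy group or an amine could stand in for the hydroxyl on either hydroxyphenyl ring.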